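This account rests on a few compounds, and the source may have more. Where it says the series, first, only, none or still open, it means among the compounds named here.

Compound 1 `CCC(C)(C)/N=c1\c(O)c(O)\c1=N/Cc1ccc(Cl)cc1Cl` gives 210 nM in a functional assay for inhibition, with Rattus norvegicus as the target; a lower number here means a stronger inhibitor, a higher number a weaker inhibitor.
Compound 2 `CCC(C)(C)/N=c1\c(O)c(O)\c1=N/Cc1ccc(C#N)cc1Cl` gives 130 nM in this assay.
Compound 3 `CC(C)(C)/N=c1\c(O)c(O)\c1=N/Cc1ccc(F)cc1Cl` gives 1400 nM in this assay.

Compound 3 stands highest of the three numbers, the weakest inhibitor here; compound 1 is nearest and compound 2 furthest, both beyond the scatter. Compound 4 `CCC(C)(C)/N=c1\c(O)c(O)\c1=N/Cc1ccc(F)cc1Cl` differs from compound 3 by methyl in place of hydrogen on a saturated chain carbon, two bonds along the chain from a double-bonded nitrogen. Going by the values given here, the only measured step, a 1.6-fold lower number from compound 1 to compound 2 (0.21 log units; within the scatter), concerns a different change and does not bear on it directly. Compounds 1 and 2 carry the 1,1-dimethylpropyl group of compound 4 and both give lower numbers than compound 3, though each also differs in a second place. A step to a lower number is therefore expected, a 4.0-fold lower number from compound 3 to compound 4 (0.60 log units; beyond the scatter), with wide uncertainty. Compound 4 is estimated at 350 nM, between 100 nM and 1200 nM.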

Compound 4, half-maximal inhibitory concentration: 1500 nM
For compound 4 the middle estimate is 4.3-fold (0.63 log units) below the measured one; measured number outside the range, above it.
By their numbers in this assay, from the lowest: compounds 2 and 1 (each within the scatter of the next); then compounds 3 and 4 (each within the scatter of the next).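

Methyl in place of hydrogen on this saturated chain carbon, which turns tert-butyl into 1,1-dimethylpropyl, leaves the number within the scatter in this assay (a 1.1-fold higher number from compound 3 to compound 4 (0.03 log units; within the scatter)). With the 1,1-dimethylpropyl group held constant, the aromatic substituent makes the clear difference, with fluoro replacing cyano (a 12-fold higher number from compound 2 to compound 4 (1.06 log units; beyond the scatter)) or chloro (a 7.1-fold higher number from compound 1 to compound 4 (0.85 log units; beyond the scatter)). No available evidence accounts for either result. Still open, on these data alone, is whether a longer chain, such as 1,1-dimethylbutyl, or an amine at this position would also leave the number within the scatter.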